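Compound 4: Methylimidazolyl Replaces Oxoimidazolidinyl

The source may report more compounds than this note shows. Statements on the series, on what has been measured and on what is new or still open speak of the compounds shown alone.

Compound 3 `CC(C)C(c1ccc(-c2ccc3cccc(F)c3c2)[nH]c1=O)N1CCNC1=O` gives 28 nM in a functional assay on CHO cells for antagonist activity at prostaglandin E2 receptor EP3 subtype (Homo sapiens), read by cAMP accumulation (a higher number here means a weaker inhibitor, a lower number a stronger inhibitor), the lowest of the three numbers, yet its steps from compound 1 `CC(C)C(c1cnc(N)s1)c1ccc(-c2ccc3cccc(F)c3c2)[nH]c1=O`, at 39 nM, and from compound 2 `CC(C)C(c1ncc[nH]1)c1ccc(-c2ccc3cccc(F)c3c2)[nH]c1=O`, at 33 nM, are a 1.4-fold lower number from compound 1 to compound 3 (0.14 log units; within the scatter) and a 1.2-fold lower number from compound 2 to compound 3 (0.07 log units; within the scatter), both within the scatter. Compound 4 `Cc1c[nH]c(C(c2ccc(-c3ccc4cccc(F)c4c3)[nH]c2=O)C(C)C)n1` differs from compound 3 by 4-methyl-1H-imidazol-2-yl in place of 2-oxoimidazolidin-1-yl on a saturated chain carbon bound to an aromatic carbon and a saturated chain carbon. The steps bearing on this are a 1.2-fold lower number from compound 1 to compound 2 (0.07 log units; within the scatter) and a 1.2-fold lower number from compound 2 to compound 3 (0.07 log units; within the scatter): three different rings on this carbon gave numbers that cannot be told apart. Because compound 2 with its imidazolyl ring gave 33 nM, compound 4 is expected to show only a 1.2-fold higher number from compound 3 to compound 4 (0.07 log units; within the scatter), nothing beyond the scatter. For compound 4 the estimate is 33 nM, expected between 15 nM and 70 nM.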

Compound 4, half-maximal inhibitory concentration: 36 nM
The estimate for compound 4 lay 1.1-fold (0.04 log units) below the measured number, within the range that was stated.
By their numbers in this assay, from the lowest: compounds 3, 2, 4 and 1 (each within the scatter of the next).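

In this assay, methyl in place of hydrogen on an aromatic carbon of the imidazole ring gives a 1.1-fold higher number from compound 2 to compound 4 (0.04 log units; within the scatter), so this added methyl produces no change that can be read. The 4-methyl-1H-imidazol-2-yl group gives a 1.3-fold higher number from compound 3 to compound 4 (0.11 log units; within the scatter) against 2-oxoimidazolidin-1-yl and a 1.1-fold lower number from compound 1 to compound 4 (0.03 log units; within the scatter) against 2-amino-1,3-thiazol-5-yl, making it a fourth group on this saturated chain carbon whose number cannot be told apart from the others. Nothing given here explains why these groups read alike.

Going by these compounds, all four groups are five-membered rings, so the effect of an open-chain amine or a carboxylic acid on this carbon remains open.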